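Methyl in Place of Cyclohexyl on a Stable Ester

A few compounds are considered here, and "the series" means these few. Any claim that something is new, unique, unknown or untested is made for them only; others in the source may bear on it.

Compound 1 `C[C@@H](O)[C@H]1C(=O)N2C(C(=O)OCOC(=O)OC3CCCCC3)=C(S[C@@H]3CN[C@H](C(=O)Nc4cccc(C(=O)O)c4)C3)[C@H](C)[C@H]12`: in a physicochemical assay for metabolic stability, read by LC-MS, in phosphate buffer, with a stated time of 3 h, at pH 7.4, tested at 50 uM (on this read-out lower numbers stand for a less stable compound and higher numbers for a more stable compound), compound 1 gives > 95%, which is a limit of the assay.
Compound 2 `Cc1oc(=O)oc1COC(=O)N1C[C@@H]2C[C@H]1C(=O)Nc1cccc(c1)C(=O)OC/C=C\COC(=O)C1=C(S2)[C@H](C)[C@@H]2[C@@H]([C@@H](C)O)C(=O)N12`: in this assay compound 2 gives > 95%, also a limit.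
Compound 3 `C[C@@H](O)[C@H]1C(=O)N2C(C(=O)OCOC(=O)OC3CCCCC3)=C(S[C@@H]3CN[C@H](C(=O)Nc4cccc(C(=O)OCOC(=O)OC5CCCCC5)c4)C3)[C@H](C)[C@H]12`: in this assay compound 3 gives > 95%, again a limit.

Compound 1 therefore stands only at a limit in this assay; no number for it is known. Going by the values given here, the single measured step that touches it, a step that the two limits leave unreadable from compound 1 to compound 3, with ((cyclohexyloxycarbonyl)oxy)methyl in place of hydrogen on an oxygen next to a carbonyl group, cannot be sized because the limit of > 95% in this assay, at which 3 of the 3 values shown sit, covers both of its ends.

Compound 4 `COC(=O)OCOC(=O)C1=C(S[C@@H]2CN[C@H](C(=O)Nc3cccc(C(=O)O)c3)C2)[C@H](C)[C@@H]2[C@@H]([C@@H](C)O)C(=O)N12` differs from compound 1 by methyl in place of cyclohexyl on an oxygen next to a carbonyl group. Among the compounds with values here, no measured step bears on this exchange. All that the data give is the limit of > 95% in this assay, at which 3 of the 3 values shown sit, with every value at the limit, so the expectation is that compound 4 also remains at that limit and that a step that the limit leaves unreadable from compound 1 to compound 4 shows no step beyond the scatter. Compound 4 is thus estimated at 96%, within a range from 88% to 100%.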

Compound 4, percent of the compound remaining: > 95%
Compound 4 was reported as a limit; the forecaster's own chance of this, stated with the estimate: 85%; the middle value is on the limit's open side.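

No step can be read between compound 1 and compound 4, because both stand at a limit in this assay: the limit of > 95% in this assay, at which 4 of the 4 values shown sit.

The compounds shown leave open whether methyl in place of cyclohexyl alters the percent remaining at all, and how any of these compounds would rank against another.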